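Allyl added to the hydroxyphenyl compound 2

A few compounds are considered here, and "the series" means these few. Any claim that something is new, unique, unknown or untested is made for them only; others in the source may bear on it.

Measured in a functional assay on the whole organism (strain Sprague-Dawley) for inhibition, with Rattus norvegicus as the target, with a stated time of 10 min; a higher number here means that more compound is needed for the effect, a lower number that less compound is needed:
- compound 1 `O=C(O)c1cnc(-c2ccccc2[N+](=O)[O-])[nH]c1=O`: > 50 mg/kg (a limit)
- compound 2 `O=C(O)c1cnc(-c2ccccc2O)[nH]c1=O`: > 5 mg/kg (a limit)

Neither compound has a numerical value, so the position of compound 2 is known only as a limit. In this assay compound 2 stands at > 5 mg/kg, which is a limit and not a number. Compound 1 stands at > 50 mg/kg, also a limit. Going by the values given here, the only measured step is a step that the two limits leave unreadable from compound 1 to compound 2, so it offers no size to carry forward, and it concerns a different change.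

Compound 3 `C=CCc1cccc(-c2ncc(C(=O)O)c(=O)[nH]2)c1O` has allyl in place of hydrogen on an aromatic carbon, ortho to a hydroxy group and meta to a large group: allyl in place of hydrogen on an aromatic carbon. Among the compounds with values here, no measured step covers this change, so the expectation is weakly founded. The expected step is an at least 2.5-fold lower number from compound 2 to compound 3 (0.39 log units; beyond the scatter), in the direction of less compound needed, and a further limit remains possible. For compound 3 the estimated value is 2 mg/kg, with an expected range of 0.3 mg/kg to 15 mg/kg.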

Compound 3, dose for 50% inhibition: > 0.5 mg/kg
Compound 3 ended at the assay's limit; the forecaster's own chance of this, stated with the estimate: 35%; the middle value lies beyond the limit too.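

In this assay compound 3 gives > 0.5 mg/kg, a limit and not a number. Going by these compounds alone, compound 2 gives > 5 mg/kg, also a limit, and no step from compound 2 to compound 3 can be read from the two limits. The compounds shown leave open whether allyl in place of hydrogen on an aromatic carbon changes the dose needed in this assay, and in which direction.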